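This account rests on a few compounds, and the source may have more. Where it says the series, first, only, none or still open, it means among the compounds named here.

Values measured so far in a functional assay on NCI-H661 cells (Homo sapiens) for antiproliferative activity, read by MTT assay, with a stated time of 72 h (a higher number here means a weaker inhibitor, a lower number a stronger inhibitor), are these.
- compound 1 `Cc1ccc(-c2noc(CCCCCCC(=O)NO)n2)cc1` gives 15800 nM
- compound 2 `COc1ccc(-c2noc(CCCCCCC(=O)NO)n2)cc1` gives 20400 nM
- compound 3 `O=C(CCCCCCc1nc(-c2ccc(F)cc2)no1)NO` gives 19400 nM

Compound 3 holds no separate rank: a 1.2-fold higher number from compound 1 to compound 3 (0.09 log units; within the scatter) and a 1.1-fold lower number from compound 2 to compound 3 (0.02 log units; within the scatter) both stay within the scatter, as does a 1.3-fold higher number from compound 1 to compound 2 (0.11 log units; within the scatter) too.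

Compound 4 `O=C(CCCCCCc1nc(-c2ccccc2Cl)no1)NO` carries 2-chlorophenyl in place of 4-fluorophenyl on an aromatic carbon with the rest unchanged. Among the compounds with values here, no measured compound carries 2-chlorophenyl, so these swaps of methyl, methoxy and fluoro bear on it only loosely. They give no ground for a step beyond the scatter in this assay and no direction. The expected change is a 1.1-fold lower number from compound 3 to compound 4 (0.03 log units; within the scatter) at most a small one. Compound 4 is expected at 18000 nM (estimated range 8000 nM to 40000 nM).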

Compound 4, half-maximal inhibitory concentration: 10300 nM
Estimate against measurement, compound 4: 1.7-fold (0.24 log units) above; the range from low to high includes it.
By their numbers in this assay, from the lowest: compounds 4, 1, 3 and 2 (each within the scatter of the next).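

In this assay, within the data shown here, 2-chlorophenyl on the aromatic carbon between two ring nitrogen atoms is the first change of the whole aryl group rather than a swap among methyl, methoxy and fluoro. Even so, it gives no step beyond the scatter (a 1.9-fold lower number from compound 3 to compound 4 (0.27 log units; within the scatter)) and (a 1.5-fold lower number from compound 1 to compound 4 (0.19 log units; within the scatter)). Nothing available here accounts for these numbers.

No listed step lies beyond the scatter, so it remains open whether any group at this position can produce one, such as an amine on the phenyl ring or a pyridine in its place. As far as these compounds go, the effect of a longer chain also remains open.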